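The compounds below may be only part of what the source reports. "The series", "measured", "known", "first", "only" and "open" are said of these compounds alone.

Measured so far:
- compound 1, `O=C1c2ccccc2N(Cc2ccccc2Cl)S(=O)(=O)N1Cc1ccccc1`, giving 60000 nM in a functional assay on MRC5 cells (Homo sapiens); a higher number here means that more compound is tolerated, a lower number that less compound is tolerated
- compound 2, `O=C1c2ccccc2N(Cc2cccc(Cl)c2)S(=O)(=O)N1Cc1ccccc1`, giving 60000 nM in this assay
- compound 3, `O=C1c2ccccc2N(Cc2ccc(Cl)c(Cl)c2)S(=O)(=O)N1Cc1ccccc1`, giving 56000 nM in this assay

Among these three, compound 3 carries the lowest number, but its nearest and furthest neighbours, compound 1 and compound 2, sit within the scatter of it, so the three are not distinguishable in this assay.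

Compound 4, `C#CCCN1c2ccccc2C(=O)N(Cc2ccccc2)S1(=O)=O`, differs from compound 3 by propargyl in place of 3,4-dichlorophenyl on a saturated chain carbon bound to a sulfonamide nitrogen in a ring. Among the measured compounds shown here, three measured steps touch the same position: no change at the digits printed from compound 1 to compound 2 (within the scatter), a 1.1-fold lower number from compound 1 to compound 3 (0.03 log units; within the scatter) and a 1.1-fold lower number from compound 2 to compound 3 (0.03 log units; within the scatter). All three stay within the scatter, yet all three only rearrange chlorine on a benzyl group that keeps its ring; none swaps the ring for a short chain, so they bear on the new change only loosely. With nothing pointing either way, no step beyond the scatter is expected in this assay.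

Compound 4 is therefore estimated at 60000 nM, in the range 30000 nM to 120000 nM, meaning an expected step of a 1.1-fold higher number from compound 3 to compound 4 (0.03 log units; within the scatter).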

Compound 4, half-maximal cytotoxic concentration: 77000 nM
Estimate against measurement, compound 4: 1.3-fold (0.11 log units) below, within the range that was stated.
By their numbers in this assay, from the lowest: compounds 3, 1, 2 and 4 (each within the scatter of the next).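

In this assay, the change from 3,4-dichlorobenzyl to but-3-yn-1-yl gives a 1.4-fold higher number from compound 3 to compound 4 (0.14 log units; within the scatter) and the matching changes from the two singly chlorinated compounds give a 1.3-fold higher number from compound 2 to compound 4 (0.11 log units; within the scatter) and a 1.3-fold higher number from compound 1 to compound 4 (0.11 log units; within the scatter). The earlier compounds shown here only moved chlorine around a ring that stayed in place, whereas these steps show that this position can lose the ring and all its chlorine, taking a short chain with a triple bond instead, with no change that can be told from the scatter. No available evidence accounts for this lack of change.

On these data alone, all of the changes shown sit at this one position and leave the number essentially where it was, so it remains open whether any group there can shift it. An amine, a carboxylic acid or a longer saturated chain at this position could still behave differently.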